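The source may report more compounds than this note shows. Statements on the series, on what has been measured and on what is new or still open speak of the compounds shown alone.

In a functional assay on MCF7 cells (Homo sapiens) (a lower number here means a stronger inhibitor of growth, a higher number a weaker inhibitor of growth), compound 1 `O=S(=O)(/C=C/c1ccccc1)Cc1ccc(Nc2ncnc3ccccc23)cc1` gives 74000 nM and compound 3 `O=S(=O)(/C=C/c1ccc(Br)cc1)Cc1ccc(Nc2ncnc3ccccc23)cc1` gives 91000 nM. These two numbers lie within the scatter of each other. Compound 2 `N#Cc1ccc(/C=C/S(=O)(=O)Cc2ccc(Nc3ncnc4ccccc34)cc2)cc1` gives > 100000 nM, which is a limit of the assay. Compound 4 `O=S(=O)(/C=C/c1ccc(Cl)cc1)Cc1ccc(Nc2ncnc3ccccc23)cc1` has not yet been measured. It differs from compound 3 by chloro in place of bromo on an aromatic carbon, para to a large group (chloro in place of bromo on an aromatic carbon). For the measured compounds named here, three measured steps bear on this place. Bromo in place of hydrogen gives a 1.2-fold higher number from compound 1 to compound 3 (0.09 log units; within the scatter). Cyano in place of hydrogen gives an at least 1.3-fold higher number from compound 1 to compound 2 (0.13 log units; that floor lies within the scatter). Bromo in place of cyano gives an at least 1.0-fold lower number from compound 2 to compound 3 (0.04 log units; that floor lies within the scatter). None of these steps is shown to go beyond the scatter, so no step beyond the scatter is expected in this assay for the exchange of bromo for chloro. The expected step is a 1.1-fold lower number from compound 3 to compound 4 (0.06 log units; within the scatter). The estimated value for compound 4 is 80000 nM, with an expected range from 45000 nM to 100000 nM.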

Compound 4, concentration for 50% growth inhibition: 52000 nM
For compound 4 the middle estimate is 1.5-fold (0.19 log units) above the measured one; the measured number falls inside the stated range.
By their numbers in this assay, from the lowest: compounds 4, 1 and 3 (each within the scatter of the next). At a limit, above all of these: compound 2.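

In this assay, the exchange of bromo for chloro on this aromatic carbon, para to a large group, gives a 1.8-fold lower number from compound 3 to compound 4 (0.24 log units; within the scatter), and chloro in place of hydrogen gives a 1.4-fold lower number from compound 1 to compound 4 (0.15 log units; within the scatter). Hydrogen, bromo and chloro at this place therefore cannot be told apart in this assay, since no step among compounds 1, 3 and 4 goes beyond the scatter. Compound 2, with cyano, stands at a limit of the assay, so its step to chloro is only a floor, an at least 1.9-fold lower number from compound 2 to compound 4 (0.28 log units; that floor lies within the scatter), and gives no exact size: the limit of > 100000 nM in this assay, at which 1 of the 4 values shown sits.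

The compounds shown leave open whether any group at this place can move the number beyond the scatter. An amine, a carboxylic acid or a methoxy group on the same carbon would test this.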